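Changing the aryl group on the amide nitrogen

This account rests on a few compounds, and the source may have more. Where it says the series, first, only, none or still open, it means among the compounds named here.

Measured compounds:
- Compound 1 `O=C(CN1CCN(c2nnc(Cc3ccncc3)c3ccccc23)CC1)Nc1ccc(F)c(F)c1` gives 3790 nM in a functional assay on A549 cells (Homo sapiens) for cytotoxicity, read by MTT assay, with a stated time of 72 h; a lower number here means a stronger inhibitor, a higher number a weaker inhibitor.
- Compound 2 `O=C(CN1CCN(c2nnc(Cc3ccccc3)c3ccccc23)CC1)Nc1ccc(F)c(F)c1` gives 10100 nM in this assay.
- Compound 3 `Cc1ccccc1NC(=O)CN1CCN(c2nnc(Cc3ccccc3)c3ccccc23)CC1` is reported as "not active" (no number reported) in this assay, with no number.

Compound 1 stands at the lowest of the two reported numbers, and the step of a 2.7-fold higher number from compound 1 to compound 2 (0.43 log units; beyond the scatter) puts compound 2 behind it by a modest margin that is still beyond the scatter. Compound 3, which carries a methyl-substituted aryl group on the amide nitrogen instead of a fluorinated one, gave no measurable number at all.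

Compound 4 `Cc1ccc(NC(=O)CN2CCN(c3nnc(Cc4ccncc4)c4ccccc34)CC2)c(C)c1` keeps everything of compound 1 except one group: 2,4-dimethylphenyl in place of 3,4-difluorophenyl on an amide-type nitrogen. Among the measured compounds shown here, no measured step covers exactly this change. For the measured compounds named here, the only hint is the pair of compound 2 and compound 3, which differ in the same region and where the fluorinated ring gives a number while the methylated ring gives none. That pairing suggests the change weakens the compound, perhaps to the point where no number is obtained.

Compound 4 is therefore expected to be weaker than compound 1, with the estimated step of a 4.0-fold higher number from compound 1 to compound 4 (0.60 log units; beyond the scatter). The estimate for compound 4 is 15000 nM, within a range from 4000 nM to 60000 nM.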

Compound 4, half-maximal inhibitory concentration: 45000 nM
The estimate for compound 4 lay 3.0-fold (0.48 log units) below the measured number; low and high end bracket the measured number.
By their numbers in this assay, from the lowest: compound 1; then compound 2; then compound 4.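

In this assay, the aryl group on the amide nitrogen turns out to be a sensitive position: a 12-fold higher number from compound 1 to compound 4 (1.07 log units; beyond the scatter) is a large step, whereas changing pyridin-4-yl to phenyl elsewhere in the molecule gave a modest one, a 2.7-fold higher number from compound 1 to compound 2 (0.43 log units; beyond the scatter). The large step appears even though 3,4-difluorophenyl and 2,4-dimethylphenyl have the same count of heavy atoms, the same kind of ring and no hydrogen-bond donors or acceptors, so these counts do not account for the difference, and compound 4 still gives a number rather than losing measurable activity altogether. Nothing available here explains why the swap weakens the compound.

Two things change together in compound 4, the kind of substituent and where it sits on the ring, so the compounds shown cannot tell which of them matters. Going by these compounds, an unsubstituted phenyl or a methoxyphenyl on the amide nitrogen would give further points of comparison, and it remains open whether the same swap has a similar effect when phenyl replaces pyridin-4-yl.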